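A few compounds are considered here, and "the series" means these few. Any claim that something is new, unique, unknown or untested is made for them only; others in the source may bear on it.

Measured compounds:
- Compound 1, `C=Cc1cc(O[C@@H]2CCNC2)cnc1Cl`: 140 nM
- Compound 2, `Clc1ncc(O[C@@H]2CCNC2)cc1-c1ccccc1`: 75 nM

Compound 2 holds the lowest number of the two in an assay on a protein complex for binding affinity to Neuronal acetylcholine receptor; alpha4/beta2 (Rattus norvegicus) (on this read-out higher numbers stand for weaker inhibition and lower numbers for stronger inhibition), but its nearest neighbour, compound 1, is within the scatter: a 1.9-fold lower number from compound 1 to compound 2 (0.27 log units; within the scatter). So on the numbers shown, compound 2 and compound 1 cannot be placed in order.

Compound 3, `Clc1ncc(O[C@@H]2CCNC2)cc1-c1ccncc1`, is not yet measured. Compared with compound 2 the change is pyridin-4-yl in place of phenyl on an aromatic carbon.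

Going by the values given here, the only measured step, from compound 1 to compound 2, swaps vinyl for phenyl at the same aromatic carbon and stays within the scatter. Among the compounds with values here, no measured pair swaps a carbon ring atom for a nitrogen ring atom, so nothing here bears directly on the change from compound 2 to compound 3. Within the data shown here, the change keeps ring size and heavy-atom count and adds one hydrogen-bond acceptor, but the data give no step of that kind to calibrate against.

The working expectation for compound 3 in this assay is therefore a step not beyond the scatter, a 1.1-fold higher number from compound 2 to compound 3 (0.03 log units; within the scatter), with an estimate of 80 nM and a range from 25 nM to 250 nM.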

Compound 3, half-maximal inhibitory concentration: 65 nM
The estimate for compound 3 lay 1.2-fold (0.09 log units) above the measured number; the range from low to high includes it.
By their numbers in this assay, from the lowest: compounds 3, 2 and 1 (each within the scatter of the next, the first and the last beyond it).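

In this assay, putting a ring nitrogen into the six-membered aromatic group ortho to a chloro group gives a 1.2-fold lower number from compound 2 to compound 3 (0.06 log units; within the scatter), so phenyl and pyridin-4-yl cannot be told apart at this position, even though pyridin-4-yl carries a hydrogen-bond acceptor that phenyl lacks. The series now also has its first step at this position beyond the scatter, a 2.2-fold lower number from compound 1 to compound 3 (0.33 log units; beyond the scatter), a modest one; the matching change to phenyl, a 1.9-fold lower number from compound 1 to compound 2 (0.27 log units; within the scatter), stays within the scatter, so this step does not set pyridin-4-yl apart from phenyl. Nothing available bears on why these numbers fall as they do.

Still open, on these data alone, is whether a ring nitrogen elsewhere in the group, as in pyridin-3-yl, or an amine or a carboxylic acid carried on the ring, would keep the number in this assay within this narrow band. Also open, as far as these compounds go, is whether a small alkyl group such as methyl at this position would give a number close to those of the vinyl and aromatic groups, or a clearly different one.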